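The source may report more compounds than this note shows. Statements on the series, on what has been measured and on what is new or still open speak of the compounds shown alone.

Measured so far in an assay on HEK293 cells for inhibition of transient receptor potential cation channel subfamily M member 8 (Homo sapiens), read by FLIPR, with stated times of 5 min and 3 min; a higher number here means a weaker inhibitor, a lower number a stronger inhibitor:

compound 1 `CON(C)C(=O)c1sc(-c2ccccc2O)nc1O`: 66 nM
compound 2 `CCn1nnc(-c2sc(-c3cccc(OC)c3)nc2O)n1`: 245 nM
compound 3 `CCn1nnc(-c2sc(-c3cccc(NC)c3)nc2O)n1`: 1020 nM

Compound 3 has the highest of the three numbers and is therefore the weakest inhibitor shown; compound 2 is its nearest neighbour, and compound 1 gives the lowest number of the three.

Compound 4 `CCn1nnc(-c2sc(-c3cccc(N)c3)nc2O)n1` has not yet been measured. It differs from compound 3 by hydrogen in place of methyl on a nitrogen on an aromatic ring. Within the data shown here, no measured pair changes exactly this: the only step that touches the same aromatic carbon is a 4.2-fold higher number from compound 2 to compound 3 (0.62 log units; beyond the scatter), which came with methylamino in place of methoxy on that carbon. That is a different change, and it gives no direct guide to taking a methyl off the nitrogen. It does show that a small alteration at this position has moved the number once already, so some movement cannot be ruled out, but there is nothing to say in which direction.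

Among the measured compounds shown here, with no precedent pointing either way, compound 4 is expected to land near compound 3. From compound 3 the expected step is a 1.1-fold lower number from compound 3 to compound 4 (0.05 log units; within the scatter), which stays within the usual scatter. The estimate for compound 4 in this assay is 900 nM, with a range from 350 nM to 2500 nM.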

Compound 4, half-maximal inhibitory concentration: 61 nM
The estimate for compound 4 lay 15-fold (1.17 log units) above the measured number, outside the stated range (below it).
By their numbers in this assay, from the lowest: compounds 4 and 1 (each within the scatter of the next); then compound 2; then compound 3.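

In this assay, among these compounds, the earlier compounds showed only that this aromatic carbon tolerates some change, but the new result shows that one methyl on the nitrogen can matter a great deal: hydrogen in its place gives a large improvement (a 17-fold lower number from compound 3 to compound 4 (1.22 log units; beyond the scatter)). Measured against methoxy on the same carbon, the two nitrogen groups pull in opposite directions, with amino giving a stronger inhibitor (a 4.0-fold lower number from compound 2 to compound 4 (0.60 log units; beyond the scatter)) and methylamino a weaker one (a 4.2-fold higher number from compound 2 to compound 3 (0.62 log units; beyond the scatter)), so the nitrogen alone does not set the outcome; the methyl on it decides which side of methoxy the number falls. Nothing available here explains why so small a change moves the number this far.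

On these data alone, it remains open whether the number keeps rising as the nitrogen carries more carbon, as it might with an ethyl chain or a dimethylamino group, or whether an acetyl group on the nitrogen would behave differently again. As far as these compounds go, it is also open whether the same swap of methyl for hydrogen would have a step of similar size on a different core, such as that of compound 1.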